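Swapping a Ring on the Core of Compound 1

The compounds below may be only part of what the source reports. "The series", "measured", "known", "first", "only" and "open" are said of these compounds alone.

Compound 1 `O=C(Nc1cccc(S(=O)(=O)C2CCCC2)c1)c1cccnc1N1CCCCC1` is the weaker of the two measured compounds: in a functional assay on OVCAR-3 cells (Homo sapiens) for antiproliferative activity (a lower number here means that less compound is needed, a higher number that more compound is needed for the effect), compound 1 gives 5030 nM, while compound 2 `CC(C)(C)NS(=O)(=O)c1cccc(NC(=O)c2ccc(NS(=O)(=O)C3(C)CC3)cc2N2CCC3(CC2)CC3)c1` gives 11 nM. Compound 2 differs from compound 1 in several places at once, so no single change can be read from that pair. Compound 3 `O=C(Nc1cccc(S(=O)(=O)C2CCCC2)c1)c1cccnc1N1CCC2(CC1)CC2` differs from compound 1 in one place: a group of 8 heavy atoms (7 carbon, 1 nitrogen; one three-membered non-aromatic ring of carbon only, one six-membered non-aromatic ring with 1 hetero atom) in place of a group of 6 heavy atoms (5 carbon, 1 nitrogen; one six-membered non-aromatic ring with 1 hetero atom), on an aromatic carbon The same entering group appears in compound 2, but the evidence is indirect, so only a modest gain is expected, a 2.5-fold lower number from compound 1 to compound 3 (0.40 log units; beyond the scatter). Compound 3 is estimated at 2000 nM, with a range from 700 nM to 6000 nM.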

Compound 3, half-maximal effective concentration: 1240 nM
Compound 3: middle estimate off by 1.6-fold (0.21 log units), on the high side; the measured number falls inside the stated range.
By their numbers in this assay, from the lowest: compound 2; then compound 3; then compound 1.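

In this assay, going by these compounds alone, replacing piperidin-1-yl with the larger group that adds a three-membered ring of carbon gives a 4.1-fold lower number from compound 1 to compound 3 (0.61 log units; beyond the scatter) as the first single-place change that can be read at this position. The aromatic carbon next to the ring nitrogen therefore accepts the added ring, and the number moves down rather than up. Nothing measured here explains this gain. As far as these compounds go, whether a morpholin-4-yl ring, a smaller pyrrolidin-1-yl ring or an open diethylamino group would do as well remains open. So does whether the same swap would give a similar step on a different core.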